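The source may hold more compounds than are shown below. What is called first, only, known or untested is meant among the compounds shown, and "the series" means these compounds.

Compound 1 `COc1ccc(CNC(=O)/C(C#N)=C/c2ccco2)cc1` is the reference point of this small set. In a functional assay on SW480 cells (Homo sapiens) for inhibition, read by MTT assay, with a stated time of 72 h (a higher number here means a weaker inhibitor of growth, a lower number a stronger inhibitor of growth), compound 1 gives 31000 nM. Compound 2 `COc1ccc(CNC(=O)/C(C#N)=C/c2ccc(Cl)o2)cc1` carries chloro in place of hydrogen on an aromatic carbon, and in this assay compound 2 gives 13000 nM, so the step of a 2.4-fold lower number from compound 1 to compound 2 (0.38 log units; beyond the scatter). Compound 3 `N#C/C(=C\c1ccccc1)C(=O)NCc1ccc(Cl)c(Cl)c1` rests on a different core; the difference between the two cores is not broken down here. In this assay compound 3 gives 49000 nM. Compound 4 `N#C/C(=C\c1ccc(Cl)cc1)C(=O)NCc1ccc(Cl)c(Cl)c1` is not yet measured and carries chloro in place of hydrogen on an aromatic carbon. This is the same kind of change as that from compound 1 to compound 2, though the place differs: here the chloro sits on a six-membered aromatic ring of carbon only, para to a large group, rather than on a five-membered ring next to the ring oxygen. Resting on the step of a 2.4-fold lower number from compound 1 to compound 2 (0.38 log units; beyond the scatter), a step of a 1.8-fold lower number from compound 3 to compound 4 (0.24 log units; within the scatter) is expected. Compound 4 is therefore estimated at 28000 nM, likely between 12000 nM and 60000 nM.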

Compound 4, concentration for 50% growth inhibition: 30000 nM
Estimate against measurement, compound 4: 1.1-fold (0.03 log units) below; the range from low to high includes it.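

Carried to a second core, the chloro change gives, in this assay, a 1.6-fold lower number from compound 3 to compound 4 (0.21 log units; within the scatter), so on this core its size cannot be told apart from repeat scatter. Set beside the earlier step, it does not differ from it: the same change on two cores in this assay, a 2.4-fold lower number (0.38 log units; beyond the scatter) from compound 1 to compound 2 and a 1.6-fold lower number (0.21 log units; within the scatter) from compound 3 to compound 4, 1.5-fold (0.16 log units) apart, within the scatter of two such steps. The two steps are therefore compatible with the change carrying over between these cores, but a single pair on each core does not show that it does, nor that it brings a real gain on the second core, and the chloro stands on a different kind of ring in each pair.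

Still open, going by these compounds, is whether a bromo group or an amine in the same place would give a similar step. Also open, on these data alone, is whether the step would hold on any further core.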